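The source may report more compounds than this note shows. Statements on the series, on what has been measured and on what is new or still open speak of the compounds shown alone.

Measured in an ADME assay on WI-38 cells (Homo sapiens) for cytotoxicity, read by MTT assay, with a stated time of 72 h; on this read-out lower numbers stand for stronger inhibition and higher numbers for weaker inhibition:
- compound 1 `O=C(CCc1cccc2c1B(O)OC2)Nc1ccccc1`: 30000 nM
- compound 2 `COc1cc(OC)cc(-c2cccc(NC(=O)CCc3cccc4c3B(O)OC4)c2)c1`: 1700 nM

Compound 2 has the lower of the two numbers. Compound 3 `COc1cc(OC)cc(-c2cccc(NC(=O)CCc3cccc4c3COB4O)c2)c1` has the same atoms as compound 2, joined differently: a group of 10 heavy atoms (7 carbon, 1 boron, 2 oxygen; one five-membered non-aromatic ring with 2 hetero atoms, one six-membered aromatic ring of carbon only) in place of a group of 10 heavy atoms (7 carbon, 1 boron, 2 oxygen; one five-membered non-aromatic ring with 2 hetero atoms, one six-membered aromatic ring of carbon only), on a saturated chain carbon, two bonds along the chain from a carbonyl carbon. Among the measured compounds shown here, the only measured step, an 18-fold lower number from compound 1 to compound 2 (1.25 log units; beyond the scatter), came with 3,5-dimethoxyphenyl in place of hydrogen on an aromatic carbon. Compound 3 keeps that group, so this large step does not size the present change. For the measured compounds named here, no measured step covers the rearrangement, so no step beyond the scatter is expected in this assay, and no direction can be favoured. The estimated step is a 1.2-fold higher number from compound 2 to compound 3 (0.07 log units; within the scatter). Compound 3 is expected at about 2000 nM, within an estimated range of 650 nM to 6000 nM.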

Compound 3, half-maximal inhibitory concentration: > 100000 nM
Compound 3 gave a limit, no number; the forecaster's own chance of this, stated with the estimate: 5%; middle value at least 50-fold (1.69 log units) away from the limit.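

In this assay, the way the atoms of the group on the saturated chain carbon are joined proves to matter on its own, with the 3,5-dimethoxyphenyl kept: there is an at least 58-fold higher number from compound 2 to compound 3 (1.76 log units; beyond the scatter). The two groups match in every count of atoms, rings, donors and acceptors, so those counts do not tell this change apart. The reading for compound 3 is a limit of the assay and not a number: the limit of > 100000 nM in this assay, at which 1 of the 3 values shown sits.

As far as these compounds go, whether the rearrangement gives a step of this size without the 3,5-dimethoxyphenyl stays open. So does what an amine or a carboxylic acid in its place would give in this assay.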